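One Chloro Fewer on the Saturated-Ring Aryl Group

A few compounds are considered here, and "the series" means these few. Any claim that something is new, unique, unknown or untested is made for them only; others in the source may bear on it.

In a functional assay, with a stated time of 20 min, tested at 20 uM (on this read-out lower numbers stand for a weaker effect and higher numbers for a stronger effect at the one concentration tested), compound 2 `COc1cc(/C=C/C(=O)C2=C(/C=C/c3ccc(O)c(OC)c3)NC(=O)NC2c2c(Cl)cccc2Cl)ccc1O` gives 33%, the lowest of the two numbers; compound 1 `COc1cc(/C=C/C(=O)C2=C(/C=C/c3ccc(O)c(OC)c3)NC(=O)NC2c2ccccc2O)ccc1O` gives 80.9%. For the measured compounds named here, the one measured step that bears on the change now considered is a number 47.9 percentage points lower from compound 1 to compound 2 (beyond the scatter). Compound 3 `COc1cc(/C=C/C(=O)C2=C(/C=C/c3ccc(O)c(OC)c3)NC(=O)NC2c2ccccc2Cl)ccc1O` differs from compound 2 by hydrogen in place of chloro on an aromatic carbon. Removing one of the two chloro groups undoes part of the step of a number 47.9 percentage points lower from compound 1 to compound 2 (beyond the scatter), so a rise is expected, smaller than that drop, as the 2-hydroxyphenyl of compound 1 is not restored. The expected step is a number 19 percentage points higher from compound 2 to compound 3 (beyond the scatter). Compound 3 is estimated at 52%, within 28% to 76%.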

Compound 3, a percentage reported as activity, at one concentration (the size of the read-out at that concentration, not a potency): 38.7%
For compound 3 the middle estimate is 13.3 percentage points above the measured one, within the range that was stated.
By their numbers in this assay, from the lowest: compounds 2 and 3 (each within the scatter of the next); then compound 1.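

In this assay hydrogen in place of chloro gives a number 5.7 percentage points higher from compound 2 to compound 3 (within the scatter) and so leaves compound 3 not separable from compound 2, which shows that the second chloro group does not account for the low number. Chloro in place of hydroxy gives a number 42.2 percentage points lower from compound 1 to compound 3 (beyond the scatter) and so ties the large gap among these three compounds to the loss of the hydroxy group. Nothing given here speaks to the reason for this. As far as these compounds go, whether a methoxy group or an amine in place of that hydroxy group would keep the higher number remains open.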